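The compounds below may be only part of what the source reports. "The series", "measured", "known", "first", "only" and "open" are said of these compounds alone.

Measured compounds:
Compound 1 `COc1cc2c(Nc3ccc(F)c(Cl)c3)ncnc2c(OC)c1OC`: 5420 nM
Compound 2 `COc1cc2c(Nc3cc(C(F)(F)F)ccc3F)ncnc2c(OC)c1OC`: 10300 nM
Compound 3 `COc1cc2c(Nc3ccc(C(F)(F)F)cc3)ncnc2c(OC)c1OC`: > 30000 nM

In a functional assay on SGC-7901 cells (Homo sapiens) for antiproliferative activity, read by MTT assay, with a stated time of 72 h (on this read-out lower numbers stand for stronger inhibition and higher numbers for weaker inhibition), compound 1 gives 5420 nM, and compound 2 gives 10300 nM, a gap that stays within the usual scatter of the measurement. For compound 3 the read-out is a limit of the assay rather than a number (the limit of > 30000 nM in this assay, at which 1 of the 3 values shown sits). Compound 4 `C#Cc1cccc(Nc2ncnc3c(OC)c(OC)c(OC)cc23)c1` has not yet been measured in this assay. It differs from compound 1 in one place: 3-ethynylphenyl in place of 3-chloro-4-fluorophenyl on a nitrogen on an aromatic ring. Within the data shown here, with no measured step of this kind at hand, the account can only expect a modest step from compound 1 to compound 4, toward a lower number or none beyond the scatter. For compound 4 the estimate is 3000 nM, within 800 nM to 15000 nM, which would mean an expected step of a 1.8-fold lower number from compound 1 to compound 4 (0.26 log units; within the scatter).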

Compound 4, half-maximal inhibitory concentration: 5820 nM
Compound 4: the middle estimate sits 1.9-fold (0.29 log units) below what was measured; the range from low to high includes it.
By their numbers in this assay, from the lowest: compounds 1, 4 and 2 (each within the scatter of the next). At a limit, above all of these: compound 3.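

In this assay, among these compounds, the step is a 1.1-fold higher number from compound 1 to compound 4 (0.03 log units; within the scatter), the first single change that can be read at this place, on a nitrogen on an aromatic ring. A 3-ethynylphenyl carrying a triple bond and neither fluorine nor chlorine thus stands in for 3-chloro-4-fluorophenyl with no change beyond the scatter. Nothing measured here gives a reason for this outcome.

On these data alone, it remains open whether an amine or a carboxylic acid on this phenyl ring, or a longer chain in place of the ethynyl group, would move the number beyond the scatter.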